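Furanyl for Methoxyphenyl on Two Chalcone Amide Cores

The source may report more compounds than this note shows. Statements on the series, on what has been measured and on what is new or still open speak of the compounds shown alone.

Compound 1 `COc1ccc(/C=C/C(=O)c2ccc(NC(=O)COc3ccc(C(C)=O)cc3)cc2)cc1`: 42%
Compound 2 `CC(=O)c1ccc(OCC(=O)Nc2ccc(C(=O)/C=C/c3ccco3)cc2)cc1`: 45%
Compound 3 `COc1ccc(/C=C/C(=O)c2ccc(NC(=O)COCc3c(-c4ccccc4)no[n+]3[O-])cc2)cc1`: 56%

All three were tested in a functional assay on the whole organism (strain albino) for inhibition, with Rattus norvegicus as the target, read by paw edema, with stated times of 30 min and 3 h, at a dose of 100 mg/kg by the oral route; a lower number here means less inhibition, a higher number more inhibition at the dose given (going by the name of the read-out). Compound 1 and compound 2 share one core and differ by furan-2-yl in place of 4-methoxyphenyl on a double-bonded chain carbon bound to a double-bonded chain carbon; that change made a number 3 percentage points higher from compound 1 to compound 2 (within the scatter). Compound 3 carries a different core; the difference between the two cores is not broken down here. Compared with compound 2 and compound 1, compound 3 stands higher in this assay by steps beyond the scatter.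

Compound 4 `O=C(COCc1c(-c2ccccc2)no[n+]1[O-])Nc1ccc(C(=O)/C=C/c2ccco2)cc1` is not yet measured. It differs from compound 3 by furan-2-yl in place of 4-methoxyphenyl on a double-bonded chain carbon bound to a double-bonded chain carbon, the same change as from compound 1 to compound 2, at the same place. The step of a number 3 percentage points higher from compound 3 to compound 4 (within the scatter) is therefore expected to be small, resting on a number 3 percentage points higher from compound 1 to compound 2 (within the scatter). For compound 4 the estimate in this assay is 59%, expected between 47% and 70%.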

Compound 4, a percentage reported as inhibition, in the whole organism at one dose (the size of the read-out at that dose, not a potency): 59%
Estimate against measurement, compound 4: no gap at the digits printed; measured number inside the range.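

In this assay, furan-2-yl in place of 4-methoxyphenyl made a number 3 percentage points higher from compound 3 to compound 4 (within the scatter). Carried from one core to the other, the change kept the same size: the same change on two cores in this assay, a number 3 percentage points higher (within the scatter) from compound 1 to compound 2 and a number 3 percentage points higher (within the scatter) from compound 3 to compound 4, 0 percentage points apart, within the scatter of two such steps. For the compounds shown here, this shows only that the swap stayed within the scatter on both cores; it does not establish a real effect of the swap on either core, nor that a larger step would carry over, and two cores say nothing about a third.

From the compounds shown here alone, it remains open whether a carboxylic acid or an amine on the ring at this place would give a step beyond the scatter. Going by these compounds, it is also open whether thiophen-2-yl would behave as furan-2-yl does on these two cores.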